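Swapping azidomethyl for a hydroxypentynyl chain

A few compounds are considered here, and "the series" means these few. Any claim that something is new, unique, unknown or untested is made for them only; others in the source may bear on it.

In an ADME assay on L1210/0 cells (Mus musculus) for cytotoxicity, with a stated time of 48 h (on this read-out higher numbers stand for weaker inhibition and lower numbers for stronger inhibition), compound 2 (`[N-]=[N+]=NCc1cn([C@H]2C[C@H](O)[C@@H](CO)O2)c(=O)[nH]c1=O`) gives 124000 nM as the higher of two exact numbers. Compound 1 (`C=C(Cl)c1cn([C@H]2C[C@H](O)[C@@H](CO)O2)c(=O)[nH]c1=O`) gives 1660 nM in that comparison. Compound 3 (`O=c1ccn([C@@H]2O[C@H](CO)[C@H](F)[C@@H]2O)c(=O)[nH]1`) gives > 200000 nM as a limit only. Compound 4 (`O=c1[nH]c(=O)n([C@H]2C[C@H](O)[C@@H](CO)O2)cc1C#CCCCO`) is still unmeasured and carries 5-hydroxypent-1-yn-1-yl in place of azidomethyl on an aromatic carbon. Among the compounds with values here, the only measured step bearing on this change is a 75-fold higher number from compound 1 to compound 2 (1.87 log units; beyond the scatter) and it is large, so swapping a group here can matter greatly. Neither group in that step matches the new chain, so only a modest move toward a lower number is expected. The estimated change is a 2.5-fold lower number from compound 2 to compound 4 (0.39 log units; beyond the scatter) with wide uncertainty. For compound 4 the estimated value is 50000 nM with an expected range from 6000 nM to 200000 nM when measured.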

Compound 4, half-maximal inhibitory concentration: > 200000 nM
Compound 4 gave a limit, no number; the forecaster's own chance of this, stated with the estimate: 30%; middle value at least 4.0-fold (0.60 log units) from the limit.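

Replacing 1-chloroethenyl on this aromatic carbon with a second, quite different group again costs heavily: an at least 120-fold higher number from compound 1 to compound 4 (2.08 log units; beyond the scatter) in this assay. Set against azidomethyl, 5-hydroxypent-1-yn-1-yl gives only an at least 1.6-fold higher number from compound 2 to compound 4 (0.20 log units; that floor lies within the scatter), so these two groups cannot be told apart. For compound 4 the result is a limit and not a number, and the true gap stays unknown: the limit of > 200000 nM in this assay, at which 2 of the 4 values shown sit.

As far as these compounds go, how far compound 4 lies past that limit remains open. So does whether an amine or a shorter chain ending in a carboxylic acid on this carbon would come closer to compound 1.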